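A few compounds are considered here, and "the series" means these few. Any claim that something is new, unique, unknown or untested is made for them only; others in the source may bear on it.

Measured compounds:
compound 1 `O=C(NCc1ccc(Cl)cc1Cl)[C@@H]1CCC(=O)N1c1cccs1` gives 229 nM
compound 2 `O=C(NCc1ccc(Cl)cc1Cl)[C@@H]1CCC(=O)N1c1ccco1` gives 244 nM
compound 3 `O=C(NCc1ccc(Cl)cc1Cl)[C@@H]1CCC(=O)N1c1cscn1` gives 256 nM

In an assay on HEK293 cells for inhibition of P2X purinoceptor 7 (Homo sapiens), read by flow cytometry, with stated times of 15 min and 1 h (on this read-out lower numbers stand for stronger inhibition and higher numbers for weaker inhibition), compound 1 holds the lowest of the three numbers, though its steps of a 1.1-fold higher number from compound 1 to compound 2 (0.03 log units; within the scatter) and a 1.1-fold higher number from compound 1 to compound 3 (0.05 log units; within the scatter) both lie within the scatter, as does a 1.0-fold higher number from compound 2 to compound 3 (0.02 log units; within the scatter). Compound 4 `O=C(NCc1ccc(Cl)cc1Cl)[C@@H]1CCC(=O)N1Cc1ccccc1Cl` has not been measured. The change is 2-chlorobenzyl in place of thiophen-2-yl on an amide-type nitrogen in a ring. The three measured steps all swap one five-membered aromatic ring for another on the same amide-type nitrogen in a ring, and none exceeds the scatter; no step among these compounds exchanges such a ring for a benzyl group. The expectation therefore rests on slight evidence, and no step beyond the scatter is expected in this assay, with wide uncertainty. Compound 4 is estimated at 300 nM (range 80 nM to 1500 nM), an expected step of a 1.3-fold higher number from compound 1 to compound 4 (0.12 log units; within the scatter).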

Compound 4, half-maximal inhibitory concentration: 3460 nM
Beside the measured number, compound 4's estimate is 12-fold (1.06 log units) below it; measured number above the stated range.
By their numbers in this assay, from the lowest: compounds 1, 2 and 3 (each within the scatter of the next); then compound 4.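

In this assay, the amide-type nitrogen in a ring proved far less tolerant than the three five-membered aromatic rings had suggested: 2-chlorobenzyl brings a 15-fold higher number from compound 1 to compound 4 (1.18 log units; beyond the scatter), a 14-fold higher number from compound 2 to compound 4 (1.15 log units; beyond the scatter) and a 14-fold higher number from compound 3 to compound 4 (1.13 log units; beyond the scatter). All three steps are large, so the weaker inhibition appears whichever of these rings leaves. Nothing among the data shown accounts for the size of these steps. Going by these compounds, it remains open whether an unsubstituted benzyl, a phenyl or a pyridin-2-yl group on this nitrogen would stay with compound 1 or fall with compound 4.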